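The compounds below may be only part of what the source reports. "The series", "measured", "known", "first", "only" and "open" are said of these compounds alone.

Measured so far:
- compound 1, `O=C(NCCO)c1cccc2c1CCN2c1cc(Cc2ccc(C(F)(F)F)cc2)ncn1`: in a functional assay on HEK293 cells for agonist activity at G-protein coupled receptor 52 (Homo sapiens), read by cAMP accumulation, with a stated time of 15 min (on this read-out lower numbers stand for smaller maximal responses and higher numbers for larger maximal responses), compound 1 gives 136%
- compound 2, `Cc1cccc(Cc2cc(N3CCc4c(C(=O)NCCO)cccc43)ncn2)c1`: in this assay compound 2 gives 144%

Compound 2 has the highest of the two numbers, with compound 1 nearest; the gap is a number 8 percentage points higher from compound 1 to compound 2 (within the scatter) and lies within the scatter. Compound 3 `O=C(NCCO)c1cccc2c1CCN2c1cc(Cc2cccc(F)c2)ncn1` differs from compound 2 by fluoro in place of methyl on an aromatic carbon. Among the measured compounds shown here, the only measured step, a number 8 percentage points higher from compound 1 to compound 2 (within the scatter), exchanged the whole aryl group at the same place and stayed within the scatter, so no step beyond the scatter is expected in this assay. Compound 3 is thus expected to give 140%, with a range from 120% to 160%. This expectation means a step of a number 4 percentage points lower from compound 2 to compound 3 (within the scatter).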

Compound 3, largest response reached (Emax), in percent of the reference or control that the assay uses: 148%
Estimate against measurement, compound 3: 8 percentage points below, and the stated range covers the measured number.
By their numbers in this assay, from the lowest: compounds 1, 2 and 3 (each within the scatter of the next, the first and the last beyond it).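

In this assay, fluoro in place of methyl on this aromatic carbon gives a number 4 percentage points higher from compound 2 to compound 3 (within the scatter) and so leaves the maximal response unchanged as far as the scatter can tell. The exchange of 4-(trifluoromethyl)phenyl for 3-fluorophenyl gives a number 12 percentage points higher from compound 1 to compound 3 (beyond the scatter) and is the only step among these compounds to pass the scatter, though modestly. Nothing available explains that step.

The compounds shown leave open how an amine or a carboxylic acid on this aromatic carbon would read. They also leave open how much of the modest step comes from the group and how much from its place on the ring, since 3-fluorophenyl and 4-(trifluoromethyl)phenyl differ in both.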